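The source may report more compounds than this note shows. Statements on the series, on what has been measured and on what is new or still open speak of the compounds shown alone.

- Compound 1 `CC(C)[C@@H](C(=O)N1CCC[C@H]1C(=O)N[C@@H](CCCNC(=N)N)C(=O)CF)N(C)C(=O)OCc1ccccc1`: > 20000 nM, a limit of the assay and not a number
- Compound 2 `CC(C)[C@H](NC(=O)c1ccc(C#N)cc1)C(=O)N1CCC[C@H]1C(=O)N[C@@H](CCCNC(=N)N)C(=O)CF`: 6660 nM
- Compound 3 `CC(C)c1ccc(C(=O)N[C@H](C(=O)N2CCC[C@H]2C(=O)N[C@@H](CCCNC(=N)N)C(=O)CF)C(C)C)cc1`: 270 nM

In a functional assay on OCI-Ly3 cells (Homo sapiens) for inhibition, read by CellTiter-Glo, with stated times of 48 h and 96 h (on this read-out lower numbers stand for stronger inhibition of growth and higher numbers for weaker inhibition of growth), compound 3 gives 270 nM, the lowest of the two exact numbers. Compound 4 `CC(C)[C@H](NC(=O)C1CCCCC1)C(=O)N1CCC[C@H]1C(=O)N[C@@H](CCCNC(=N)N)C(=O)CF` has cyclohexyl in place of 4-isopropylphenyl on a carbonyl carbon. The closest guide is a 25-fold lower number from compound 2 to compound 3 (1.39 log units; beyond the scatter), a change on the aromatic ring alone. The wider changes an at least 3.0-fold lower number from compound 1 to compound 2 (0.47 log units; beyond the scatter) and an at least 74-fold lower number from compound 1 to compound 3 (1.86 log units; beyond the scatter) also show that this end of the molecule can move the number far. For the measured compounds named here, no measured step replaces the aromatic ring itself, so the guide is loose. A moderate rise is expected, and the estimated step is a 4.4-fold higher number from compound 3 to compound 4 (0.65 log units; beyond the scatter). For compound 4 the expected value is 1200 nM, with an estimated range of 300 nM to 6000 nM.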

Compound 4, concentration for 50% growth inhibition: 940 nM
The estimate for compound 4 lay 1.3-fold (0.11 log units) above the measured number, within the range that was stated.
By their numbers in this assay, from the lowest: compound 3; then compound 4; then compound 2. At a limit, above all of these: compound 1.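

In this assay, an aromatic ring on this carbonyl carbon is not required for growth inhibition, although cyclohexyl in place of 4-isopropylphenyl gives some ground away (a 3.5-fold higher number from compound 3 to compound 4 (0.54 log units; beyond the scatter)). Cyclohexyl also outperforms 4-cyanophenyl (a 7.1-fold lower number from compound 2 to compound 4 (0.85 log units; beyond the scatter)), so the non-aromatic ring falls between the two aromatic ones and aromaticity alone does not set the order. Compound 1 stands at a limit of the assay, so the step to cyclohexyl (an at least 21-fold lower number from compound 1 to compound 4 (1.32 log units; beyond the scatter)) is only a bound.

From the compounds shown here alone, it remains open whether an isopropyl group on the cyclohexyl ring would restore the lost ground, and how a ring carrying an amine or a carboxylic acid would behave.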